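Shifting the nitro group: expectation for compound 3

The compounds below may be only part of what the source reports. "The series", "measured", "known", "first", "only" and "open" are said of these compounds alone.

Measured so far:
compound 1 `CCOc1c(Br)cc(/C=C2\CCC/C(=C\c3cccc([N+](=O)[O-])c3)C2=O)cc1OC` — 10.8 ug/mL
compound 2 `CCCOc1c(Br)cc(/C=C2\CCC/C(=C\c3cccc([N+](=O)[O-])c3)C2=O)cc1OC` — 1.51 ug/mL

In a functional assay on SK-N-MC cells (Homo sapiens) for cytotoxicity, read by MTT assay (a higher number here means a weaker inhibitor, a lower number a stronger inhibitor), compound 1 gives 10.8 ug/mL, the highest of the two numbers measured. Within the data shown here, the only other measured compound is compound 2, and the single measured step is a 7.2-fold lower number from compound 1 to compound 2 (0.85 log units; beyond the scatter).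

Compound 3 `CCOc1c(Br)cc(/C=C2\CCC/C(=C\c3ccc([N+](=O)[O-])cc3)C2=O)cc1OC` is unmeasured. Its change from compound 1 is 4-nitrophenyl in place of 3-nitrophenyl on a double-bonded chain carbon bound to a double-bonded ring carbon. Among the measured compounds shown here, the one measured step concerns the chain on the ring oxygen, a different place, so it does not bear on this change; no measured step informs a swap between the two nitrophenyl groups. With nothing to anchor a direction, the estimated step is a 1.2-fold lower number from compound 1 to compound 3 (0.08 log units; within the scatter), that is, none expected beyond the scatter, with wide uncertainty. Compound 3 is therefore expected in this assay near 9 ug/mL, between 3 ug/mL and 27 ug/mL.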

Compound 3, half-maximal inhibitory concentration: 3.91 ug/mL
Compound 3: the middle estimate sits 2.3-fold (0.36 log units) above what was measured; measured number inside the range.
By their numbers in this assay, from the lowest: compound 2; then compound 3; then compound 1.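

Within this assay, the change to 4-nitrophenyl in place of 3-nitrophenyl on a double-bonded chain carbon bound to a double-bonded ring carbon gives a 2.8-fold lower number from compound 1 to compound 3 (0.44 log units; beyond the scatter) with the shared core and the chain on the ring oxygen unchanged. The nitrophenyl group is therefore a second place in the series where one change moves the number beyond the scatter, alongside the chain on the ring oxygen, where the step is a 7.2-fold lower number from compound 1 to compound 2 (0.85 log units; beyond the scatter) in this series. No evidence is available on what separates the two nitrophenyl groups.

From the compounds shown here alone, whether the two favourable changes add up when combined in one compound remains open. Also open, going by these compounds, is how this position would read with an amine or a nitrile on the phenyl ring in place of the nitro group.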